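Working notes: aryl exchange from compound 3 to compound 4

The source may report more compounds than this note shows. Statements on the series, on what has been measured and on what is new or still open speak of the compounds shown alone.

Measured so far in a functional assay on HepG2 cells (Homo sapiens) for cytotoxicity, read by MTT assay, with a stated time of 72 h; on this read-out lower numbers stand for stronger inhibition and higher numbers for weaker inhibition
- compound 1 (`COc1cc2ncnc(Nc3ccc(F)c(Cl)c3)c2cc1NC(=O)N/N=C/c1ccc(C#N)cc1`) gives 34100 nM
- compound 2 (`COc1ccc(/C=N/NC(=O)Nc2cc3c(Nc4ccc(F)c(Cl)c4)ncnc3cc2OC)cc1`) gives 21300 nM
- compound 3 (`COc1cc2ncnc(Nc3ccc(F)c(Cl)c3)c2cc1NC(=O)N/N=C/c1ccc(OC)c(OC)c1OC`) gives 31200 nM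

Compound 3 at 31200 nM is not separated from compound 1 or compound 2, as all three values lie within the scatter of one another. Compound 4 (`CCN(CC)c1ccc(/C=N/NC(=O)Nc2cc3c(Nc4ccc(F)c(Cl)c4)ncnc3cc2OC)c(O)c1`) carries 4-(diethylamino)-2-hydroxyphenyl in place of 2,3,4-trimethoxyphenyl on a carbon with a double bond to nitrogen. The measured exchanges at this place are small: a 1.6-fold lower number from compound 1 to compound 2 (0.20 log units; within the scatter), a 1.1-fold lower number from compound 1 to compound 3 (0.04 log units; within the scatter) and a 1.5-fold higher number from compound 2 to compound 3 (0.17 log units; within the scatter). On that basis, no step beyond the scatter is expected in this assay. Among the compounds with values here, no measured compound carries a hydroxy or diethylamino group, so the range is kept wide. The expected change is a 1.4-fold lower number from compound 3 to compound 4 (0.15 log units; within the scatter) and remains an estimate. Compound 4 is estimated at 22000 nM (expected range 7000 nM to 50000 nM).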

Compound 4, half-maximal inhibitory concentration: 29300 nM
For compound 4 the middle estimate is 1.3-fold (0.12 log units) below the measured one; the range from low to high includes it.
By their numbers in this assay, from the lowest: compounds 2, 4, 3 and 1 (each within the scatter of the next).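

With 4-(diethylamino)-2-hydroxyphenyl on the carbon with a double bond to nitrogen, the series in this assay now includes a hydroxy and a diethylamino group at this place, and the steps to all three earlier compounds lie within the scatter (a 1.1-fold lower number from compound 3 to compound 4 (0.03 log units; within the scatter)), (a 1.4-fold higher number from compound 2 to compound 4 (0.14 log units; within the scatter)) and (a 1.2-fold lower number from compound 1 to compound 4 (0.07 log units; within the scatter)). The four aryl groups shown at this place, including the new one, are therefore not separated from one another on this read-out. No available data bear on why these values are not separated.

As far as these compounds go, it remains open whether a non-aromatic group at this place, such as a longer alkyl chain, or an aryl group bearing a carboxylic acid would give a step beyond the scatter. The shared core is identical in all four compounds, so its contribution to these values cannot be read.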